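A few compounds are considered here, and "the series" means these few. Any claim that something is new, unique, unknown or untested is made for them only; others in the source may bear on it.

In a physicochemical assay for solubility, in phosphate buffer, at pH 7 (a higher number here means a more soluble compound, a lower number a less soluble compound), compound 1 `CC(=O)Nc1cn2cc(-c3cc(NC(=O)c4ccc(CN5CCN(C)CC5)c(C(F)(F)F)c4)ccc3C)ccc2n1` gives 4600 nM. Compound 2 `CC(=O)Nc1cn2cc(-c3cc(NC(=O)c4cccc(C(F)(F)F)c4)ccc3C)ccc2n1` gives < 400 nM, which is a limit of the assay and not a number. For the measured compounds named here, one measured step bears on what follows: an at least 11-fold lower number from compound 1 to compound 2 (1.06 log units; beyond the scatter), a large change beyond the scatter, in which hydrogen replaces (4-methylpiperazin-1-yl)methyl on an aromatic carbon.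

Compound 3 `CC(=O)Nc1cn2cc(-c3cc(NC(=O)c4cc(N5CCN(C)C[C@@H]5C)cc(C(F)(F)F)c4)ccc3C)ccc2n1` starts from compound 2 and makes a related change: 2,4-dimethylpiperazin-1-yl in place of hydrogen on an aromatic carbon. Here 2,4-dimethylpiperazin-1-yl replaces hydrogen on an aromatic carbon, meta to a trifluoromethyl group. This is not the group found in compound 1, so the earlier step can serve only as a rough guide, read in reverse. Its direction suggests a higher number, perhaps of similar size. The expected change is an at least 6.2-fold higher number from compound 2 to compound 3 (0.79 log units; beyond the scatter). For compound 3, the estimated value is 2500 nM, with an expected range of 600 nM to 9000 nM.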

Compound 3, solubility: 122000 nM
Estimate against measurement, compound 3: 49-fold (1.69 log units) below, and the stated range ends below it.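

In this assay, placing 2,4-dimethylpiperazin-1-yl on an aromatic carbon, meta to a trifluoromethyl group, gives an at least 300-fold higher number from compound 2 to compound 3 (2.48 log units; beyond the scatter). The earlier step concerned a different group, (4-methylpiperazin-1-yl)methyl, so this result adds direct evidence that a hydrogen replaced at this position by a ring with 2 hetero atoms goes with a large rise in the read-out. Compound 2 stands at a limit and not a number, so the exact size of this step stays unknown: the limit of < 400 nM in this assay, at which 1 of the 3 values shown sits.

The compounds shown cannot separate the part played by the ring itself from that of its two methyl groups or its one defined stereocentre. On these data alone, it also remains open whether a morpholine ring, a simple primary amine or a carboxylic acid at this position would move the number in the same direction.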